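Isopropyl replaces carbamoylmethyl on the ring nitrogen

This account rests on a few compounds, and the source may have more. Where it says the series, first, only, none or still open, it means among the compounds named here.

Compound 1 `COc1cc2c(cc1NS(=O)(=O)c1cccc(Cl)c1Cl)[nH]c(=O)n2C`: 200 nM
Compound 2 `COc1cc2c(cc1NS(=O)(=O)c1cccc(Cl)c1Cl)[nH]c(=O)n2CC(N)=O`: 457 nM

Both compounds were tested in a functional assay on CHO cells for antagonist activity at C-C chemokine receptor type 4 (Homo sapiens), read by radioligand binding and GTPgammaS binding; a higher number here means a weaker inhibitor, a lower number a stronger inhibitor. Compound 2 has the higher of the two numbers, since a 2.3-fold higher number from compound 1 to compound 2 (0.36 log units; beyond the scatter). Compound 3 `COc1cc2c(cc1NS(=O)(=O)c1cccc(Cl)c1Cl)[nH]c(=O)n2C(C)C` differs from compound 2 by isopropyl in place of carbamoylmethyl on an aromatic nitrogen. Among the compounds with values here, the only measured step that bears on this is a 2.3-fold higher number from compound 1 to compound 2 (0.36 log units; beyond the scatter); removing the carbamoyl group in compound 3 would be expected to undo that modest rise, while isopropyl itself has no measured precedent here. A modestly lower number is therefore expected, a 2.3-fold lower number from compound 2 to compound 3 (0.36 log units; beyond the scatter). Compound 3 is estimated at 200 nM, in a range from 80 nM to 500 nM.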

Compound 3, half-maximal inhibitory concentration: 1000 nM
Compound 3: middle estimate off by 5.0-fold (0.70 log units), on the low side, outside the stated range (above it).
By their numbers in this assay, from the lowest: compound 1; then compound 2; then compound 3.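

Removing the carbamoyl group does not by itself lower the number at this ring nitrogen: isopropyl in place of carbamoylmethyl gives a 2.2-fold higher number from compound 2 to compound 3 (0.34 log units; beyond the scatter). The size of the simple carbon group also matters here, since isopropyl in place of methyl gives a 5.0-fold higher number from compound 1 to compound 3 (0.70 log units; beyond the scatter), leaving methyl with the lowest number of the three compounds. Nothing measured here explains either step. Still open, on these data alone, is how an ethyl group, a longer chain ending in an amine, or a plain hydrogen on this nitrogen would compare.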